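The source may hold more compounds than are shown below. What is called first, only, known or untested is meant among the compounds shown, and "the series" means these compounds.

Of the compounds shown here, three built on one shared core have been measured in an assay on HEK293 cells for antagonist activity at P2X purinoceptor 7 (Homo sapiens), read by fluorescence, with a stated time of 2 h; a higher number here means a weaker inhibitor, a lower number a stronger inhibitor. Compound 1 `O=C(c1ccc(Cl)c(C(F)(F)F)c1)N1CCC(n2cncc2-c2ccc(OS(=O)(=O)c3ccccc3)cc2)CC1` gives 702 nM, compound 2 `Nc1cccc(S(=O)(=O)Oc2ccc(-c3cncn3C3CCN(C(=O)c4ccc(Cl)c(C(F)(F)F)c4)CC3)cc2)c1` gives 565 nM, and compound 3 `N#Cc1cccc(S(=O)(=O)Oc2ccc(-c3cncn3C3CCN(C(=O)c4ccc(Cl)c(C(F)(F)F)c4)CC3)cc2)c1` gives 73 nM, the lowest of the three numbers. The steps of a 9.6-fold lower number from compound 1 to compound 3 (0.98 log units; beyond the scatter) and a 7.7-fold lower number from compound 2 to compound 3 (0.89 log units; beyond the scatter) both go with the arrival of the cyano group, whereas the step of a 1.2-fold lower number from compound 1 to compound 2 (0.09 log units; within the scatter) changes little. Compound 4 `O=C(c1ccc(Cl)c(C(F)(F)F)c1)N1CCC(n2cncc2-c2ccc(OS(=O)(=O)c3cccc4cnccc34)cc2)CC1` differs from compound 3 by isoquinolin-5-yl in place of 3-cyanophenyl on a sulfonyl sulfur. Within the data shown here, no measured step exchanges one ring for another, so only the cyano steps bear on this change, and they show that the number rose whenever the cyano group was absent, as in compound 1 and compound 2. A modest rise in this assay is therefore expected, a 3.4-fold higher number from compound 3 to compound 4 (0.53 log units; beyond the scatter). Compound 4 is expected to give 250 nM, with a likely range from 80 nM to 800 nM.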

Compound 4, half-maximal inhibitory concentration: 45 nM
The estimate for compound 4 lay 5.6-fold (0.74 log units) above the measured number; the whole stated range lies above it.
By their numbers in this assay, from the lowest: compounds 4 and 3 (each within the scatter of the next); then compounds 2 and 1 (each within the scatter of the next).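

In this assay, isoquinolin-5-yl on the sulfonyl sulfur does as well as 3-cyanophenyl, with a 1.6-fold lower number from compound 3 to compound 4 (0.21 log units; within the scatter), a step within the scatter. Against the other two groups, the new two-ring group stands well clear, with a 13-fold lower number from compound 2 to compound 4 (1.10 log units; beyond the scatter) and a 16-fold lower number from compound 1 to compound 4 (1.19 log units; beyond the scatter), so a nitrile is not required for a low number at this position. Nothing available explains these differences. Going by these compounds, whether the ring nitrogen of isoquinolin-5-yl matters remains open, and a naphthyl group, with carbon in its place, would test this. On these data alone, how a carboxylic acid on the phenyl ring would compare with the nitrile is also open.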